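This account rests on a few compounds, and the source may have more. Where it says the series, first, only, none or still open, it means among the compounds named here.

Measured compounds:
compound 1 `CN(C)CCCCOc1ccccc1/C=C/c1cccc(Cl)c1`, in a functional assay on the whole organism with Mus musculus as the target, in the maximal electroshock model, at a dose of 50 mg/kg by the oral route (on this read-out higher numbers stand for more inhibition at the one dose given (going by the name of the read-out) and lower numbers for less inhibition), compound 1 gives 14.3%
compound 2 `COc1ccccc1/C=C/c1ccccc1OCCCCN(C)C`, in this assay compound 2 gives 0%

Of the two compounds measured, compound 1 stands highest in this assay; the nearest is compound 2, and the step of a number 14.3 percentage points lower from compound 1 to compound 2 (beyond the scatter) lies beyond the scatter, so on these two numbers compound 1 has the higher inhibition. Between compound 1 and compound 2 the structures differ in one place: 2-methoxyphenyl stands in place of 3-chlorophenyl on a double-bonded chain carbon bound to a double-bonded chain carbon.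

Compound 3 `CN1CCN(CCCCOc2ccccc2/C=C/c2cccc(Cl)c2)CC1` is not yet measured. It differs from compound 1 at another place: 4-methylpiperazin-1-yl in place of dimethylamino on a saturated chain carbon, four bonds along the chain from an oxygen on an aromatic ring. Among the compounds with values here, no measured step touches this part of the molecule. Within the data shown here, the one measured step, a number 14.3 percentage points lower from compound 1 to compound 2 (beyond the scatter), concerns a different place in the molecule. Nothing measured therefore speaks for a shift in either direction between compound 1 and compound 3. With the chain and both aromatic groups of compound 1 kept, the read-out of compound 3 in this assay is expected to stay close to that of compound 1, with a step of a number 0.7 percentage points higher from compound 1 to compound 3 (within the scatter) not beyond the scatter. Compound 3 is therefore estimated at 15%, within a range of 0% to 40%.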

Compound 3, a percentage reported as inhibition, in the whole organism at one dose (the size of the read-out at that dose, not a potency): 0%
For compound 3 the middle estimate is 15 percentage points above the measured one; the measured number falls inside the stated range.
By their numbers in this assay, from the lowest: compounds 2 and 3 (each within the scatter of the next); then compound 1.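

Exchanging dimethylamino for 4-methylpiperazin-1-yl on the saturated chain carbon, four bonds along the chain from an oxygen on an aromatic ring, gives a number 14.3 percentage points lower from compound 1 to compound 3 (beyond the scatter) in this assay and so shows that this end of the molecule, which the earlier pair left untouched, also bears on the read-out. Compound 1 now loses inhibition at two separate places, the other being the change of aryl group with a number 14.3 percentage points lower from compound 1 to compound 2 (beyond the scatter) as its step, although the new change alone brings in a six-membered non-aromatic ring and takes the group from 3 to 7 heavy atoms, and this single exchange cannot separate those two features. Nothing measured alongside these numbers accounts for the drop.

The compounds shown leave open whether another amine at this place, such as piperidin-1-yl, pyrrolidin-1-yl or morpholin-4-yl, would keep the reading of compound 1 or lose it as well, which would help to tell the ring itself from the second ring nitrogen. They also leave open whether a shorter or longer chain carrying the 4-methylpiperazin-1-yl group would restore any inhibition at this one dose.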